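Ring Swap on Compound 1: What Binding Value to Expect

The source may hold more compounds than are shown below. What is called first, only, known or untested is meant among the compounds shown, and "the series" means these compounds.

Measured in an assay on CHO-K1 cells for displacement of a labelled ligand from adenosine receptor A1 (Homo sapiens), with a stated time of 2 h; on this read-out higher numbers stand for weaker inhibition and lower numbers for stronger inhibition:
compound 1, `CC(C)(NC(=O)COc1ccc2[nH]c(=O)c(-c3ccccn3)c(CCc3ccccc3)c2c1)c1ccccc1`, gives 1370 nM
compound 2, `COCCCNC(=O)COc1ccc2c(c1)c(CCc1ccccc1)c(-c1ccc(F)cc1F)c(=O)n2C`, gives 3620 nM

Going by the values given here, only these two compounds have numbers so far. Compound 1 holds the lower of the two, and the gap to compound 2 lies beyond the usual scatter of this assay, so compound 1 can be called the stronger binder of the pair. Compound 2 differs from compound 1 in several places at once, so its value says nothing about any single change.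

Compound 3, `Cc1cc(-c2c(CCc3ccccc3)c3cc(OCC(=O)NC(C)(C)c4ccccc4)ccc3[nH]c2=O)on1`, has not yet been measured. It differs from compound 1 in one place: 3-methyl-1,2-oxazol-5-yl in place of pyridin-2-yl on an aromatic carbon. Among the compounds with values here, no measured pair shows what such a swap does on this core, so there is no step to lean on, only the value of compound 1 as a starting point. A shift beyond the scatter is possible in either direction, but with nothing pointing one way, the expected step from compound 1 to compound 3 is a small loss, a 1.5-fold higher number from compound 1 to compound 3 (0.16 log units; within the scatter). Compound 3 is therefore expected to give about 2000 nM, most likely between 500 nM and 8000 nM.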

Compound 3, inhibition constant: 12 nM
The estimate for compound 3 lay 170-fold (2.22 log units) above the measured number; the measured number lies below the stated range.
By their numbers in this assay, from the lowest: compound 3; then compound 1; then compound 2.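

Swapping pyridin-2-yl for 3-methyl-1,2-oxazol-5-yl in this assay gives a 110-fold lower number from compound 1 to compound 3 (2.06 log units; beyond the scatter), so the ring held at this position, ortho to a phenethyl group, can matter a great deal for the measured binding, which the earlier values alone could not reveal. The step comes without any change in size by heavy-atom count, as both groups have 6 heavy atoms and no net charge; what differs is that a six-membered aromatic ring with 1 hetero atom gives way to a five-membered aromatic ring with 2 hetero atoms, and 1 hydrogen-bond acceptor gives way to 2. Nothing available here explains why this single swap has so large an effect.

From the compounds shown here alone, it remains open how much of the gain belongs to the new ring and how much to its methyl, a question that a plain 1,2-oxazol-5-yl or a 3-ethyl-1,2-oxazol-5-yl at this position would help to answer. Going by these compounds, it is also open whether the same swap would bring a comparable gain on a differently substituted compound such as compound 2.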